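A few compounds are considered here, and "the series" means these few. Any claim that something is new, unique, unknown or untested is made for them only; others in the source may bear on it.

Of the compounds shown here, three have been measured in an assay on CHO cells for displacement of a labelled ligand from 5-hydroxytryptamine receptor 1D (Homo sapiens); on this read-out lower numbers stand for stronger inhibition and higher numbers for weaker inhibition. Compound 1 `C[C@@H](NC1CCN(CCCc2c[nH]c3ccc(-n4cnnc4)cc23)CC1)c1ccccc1` gives 0.4 nM and compound 2 `CC(=O)Nc1ccc([C@H](C)NCC2CCN(CCCc3c[nH]c4ccc(-n5cnnc5)cc34)CC2)cc1` gives 0.6 nM; these two numbers lie within the usual scatter of each other. Compound 3 `CN(CC1CCN(CCCc2c[nH]c3ccc(-n4cnnc4)cc23)CC1)C(=O)Nc1ccccc1` gives 5.9 nM, the highest of the three and beyond the scatter from both others, so it is the weakest binder of the measured set.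

Compound 4 `C[C@H](NCC1CCN(CCCc2c[nH]c3ccc(-n4cnnc4)cc23)CC1)c1ccccc1` has not yet been measured. It differs from compound 3 in one place: (1-phenylethyl)amino in place of methyl(phenylcarbamoyl)amino on a saturated chain carbon bound to a saturated ring carbon. The group that enters is the same kind of (1-phenylethyl)amino that compounds 1 and 2 carry, and both of those gave numbers far below compound 3. Compound 4 is therefore expected to move downward, with a step of a 7.4-fold lower number from compound 3 to compound 4 (0.87 log units; beyond the scatter), beyond the scatter. The estimate for compound 4 in this assay is 0.8 nM, within a range from 0.3 nM to 2.5 nM.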

Compound 4, half-maximal inhibitory concentration: 4.4 nM
Compound 4: middle estimate off by 5.5-fold (0.74 log units), on the low side; the measured number lies above the stated range.
By their numbers in this assay, from the lowest: compounds 1 and 2 (each within the scatter of the next); then compounds 4 and 3 (each within the scatter of the next).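

In this assay, among the compounds shown here, the swap to (1-phenylethyl)amino on a saturated chain carbon bound to a saturated ring carbon gives only a 1.3-fold lower number from compound 3 to compound 4 (0.13 log units; within the scatter), so this group alone does not bring the low numbers of the earlier compounds. Two single changes matter more: hydrogen in place of acetamido on an aromatic carbon gives a 7.3-fold higher number from compound 2 to compound 4 (0.87 log units; beyond the scatter), and ((1-phenylethyl)amino)methyl in place of (1-phenylethyl)amino on a saturated ring carbon gives an 11-fold higher number from compound 1 to compound 4 (1.04 log units; beyond the scatter) here. No measured evidence accounts for these steps.

Going by these compounds, how a methoxy group or a fluorine in place of acetamido on that aromatic carbon would read remains open.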